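The compounds below may be only part of what the source reports. "The series", "measured", "known", "first", "only" and "open" are said of these compounds alone.

The shared core is carried by compound 1 `CN(C)C[C@@H]1CN(C)C(=O)O1`, compound 2 `CN1C[C@@H](C[N+](C)(C)C)OC1=O` and compound 3 `CN1C[C@H](C[N+](C)(C)C)OC1=O`. In an assay on Hippocampus for displacement of a labelled ligand from Neuronal acetylcholine receptor; alpha4/beta2 (Rattus norvegicus) (a lower number here means a stronger inhibitor, a higher number a weaker inhibitor), compound 1 gives 2660 nM, compound 2 gives 3610 nM and compound 3 gives 3100 nM. Compound 2 stands at the highest of the three numbers, yet both gaps are within the scatter: a 1.4-fold higher number from compound 1 to compound 2 (0.13 log units; within the scatter) and a 1.2-fold lower number from compound 2 to compound 3 (0.07 log units; within the scatter), the second resting on (the fact that compounds 2 and 3 differ only in the configuration as drawn). Compound 4 `C[N+](C)(C)C[C@@H]1CNC(=O)O1` is not yet measured. It differs from compound 2 by hydrogen in place of methyl on an amide-type nitrogen in a ring. Neither measured step touches the amide-type nitrogen in the ring: one exchanges the group on the saturated chain carbon, the other changes only the drawn configuration, and both stayed within the scatter. No step in the set therefore bears directly on this change, and the measured steps give no reason to expect a move in this assay. For compound 4 the expected step is a 1.0-fold lower number from compound 2 to compound 4 (0.00 log units; within the scatter), none beyond the scatter. Compound 4 is accordingly estimated at 3600 nM, between 1200 nM and 11000 nM.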

Compound 4, inhibition constant: 429 nM
The estimate for compound 4 lay 8.4-fold (0.92 log units) above the measured number; the measured number lies below the stated range.
By their numbers in this assay, from the lowest: compound 4; then compounds 1, 3 and 2 (each within the scatter of the next).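

In this assay, for the compounds shown here, there is an 8.4-fold lower number from compound 2 to compound 4 (0.93 log units; beyond the scatter) with hydrogen in place of methyl on the amide-type nitrogen in the ring, the only step that lies beyond the scatter. Going by these compounds alone, this position therefore affects the number in a way the earlier steps did not show: the exchange on the saturated chain carbon and the change in drawn configuration both stayed within the scatter. Nothing at hand accounts for this step.

From the compounds shown here alone, the finding rests on a single pair, so it remains open whether ethyl or a longer chain on this nitrogen would give a number closer to that of the methyl compounds or to that of the hydrogen compound. Going by these compounds, it also remains open whether the same replacement would give a similar step with the chain group of compound 1 or the drawn configuration of compound 3.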